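The compounds below may be only part of what the source reports. "The series", "measured", "known", "first", "only" and "open" are said of these compounds alone.

Compound 1 `CCCC(=O)N(C)c1ccc(C(O)(C(F)(F)F)C(F)(F)F)cc1` gives in an ADME assay on Li23 cells (Homo sapiens) for cytotoxicity, read by WST assay (a higher number here means that more compound is tolerated, a lower number that less compound is tolerated), only a limit, > 100000 nM, and no number. Compound 2 `CN(C(=O)c1cccnc1)c1ccc(C(O)(C(F)(F)F)C(F)(F)F)cc1` gives 63000 nM in this assay, the only number shown. The step of an at least 1.5-fold lower number from compound 1 to compound 2 (0.20 log units; that floor lies within the scatter) is bounded by the limit of > 100000 nM in this assay, at which 1 of the 2 values shown sits. Compound 3 `CN(C(=O)Nc1ccccc1)c1ccc(C(O)(C(F)(F)F)C(F)(F)F)cc1` differs from compound 2 by anilino in place of pyridin-3-yl on a carbonyl carbon. Among the measured compounds shown here, only that one measured step bears on this change, and it lies within the scatter, so no shift beyond the scatter is expected here. The expected step is a 1.1-fold higher number from compound 2 to compound 3 (0.05 log units; within the scatter), inside the scatter. Compound 3 is therefore estimated at 70000 nM in this assay, expected between 30000 nM and 150000 nM.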

Compound 3, half-maximal cytotoxic concentration: > 20000 nM
Compound 3: a limit, no number; the forecaster's own chance of this, stated with the estimate: 35%; the middle value lies beyond the limit too.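

In this assay compound 3 gives only a limit, > 20000 nM, and the steps to it from compound 1 and compound 2 cannot be read. Going by these compounds, whether anilino in place of pyridin-3-yl on a carbonyl carbon shifts the number at all stays open.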